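The compounds below may be only part of what the source reports. "The series", "measured", "known", "first", "only" and "open" are said of these compounds alone.

Compound 2 `Cc1cc(=O)n([C@@H]2O[C@H](COP(=O)(O)O)[C@@H](O)[C@H]2O)c(=O)[nH]1` and compound 1 `CCCc1cc(=O)n([C@@H]2O[C@H](COP(=O)(O)OP(=O)(O)O)[C@@H](O)[C@H]2O)c(=O)[nH]1` share a core and were both examined in an in vitro functional assay on 1321-N1 cells for agonist activity at P2Y purinoceptor 2 (Homo sapiens); on this read-out higher numbers stand for an effect only at larger amounts of compound and lower numbers for an effect already at smaller amounts. Compound 2 gives > 100000 nM in this assay, which is a limit of the assay and not a number. Compound 1 gives > 100000 nM in this assay, again a limit rather than a number. Among the measured compounds shown here, compound 2 therefore stands at the limit of > 100000 nM in this assay, at which 2 of the 2 values shown sit; since neither measured compound yields a number, no step between measured compounds can be drawn, and the two values show only that neither compound produces an effect within the range covered. Compound 3 `CCCc1cc(=O)n([C@@H]2O[C@H](COP(=O)(O)O)[C@@H](O)[C@H]2O)c(=O)[nH]1` is the next member and has not yet been measured in this assay. It differs from compound 2 by ethyl in place of hydrogen on a saturated chain carbon bound to an aromatic carbon. With both measured compounds resting at the limit, no direction can be read from the numbers, and no movement beyond the scatter is expected from this change. The expected step in this assay is a step that the limit leaves unreadable from compound 2 to compound 3. Compound 3 is accordingly estimated at 200000 nM in this assay, with a range from 50000 nM to 1000000 nM, and is expected to be reported once more only as a limit.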

Compound 3, half-maximal effective concentration: > 100000 nM
Compound 3: no number, only a limit; the forecaster's own chance of this, stated with the estimate: 85%; the middle value is on the limit's open side.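

In this assay, compound 1, compound 2 and compound 3 give no number, so no step among them can be read; all three rest at one limit of the assay: the limit of > 100000 nM in this assay, at which 3 of the 3 values shown sit.

The compounds shown leave open how far past this limit each one lies and whether any change to the shared core would bring an effect within the range covered.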